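Chloro for Fluoro on Aryl Methylsulfonyl Imidazoline Amines

The source may report more compounds than this note shows. Statements on the series, on what has been measured and on what is new or still open speak of the compounds shown alone.

Compound 1 `CS(=O)(=O)c1ccc(F)cc1NCC1=NCCN1`: < 6310 nM
Compound 2 `CS(=O)(=O)c1cc(F)ccc1NCC1=NCCN1`: < 6310 nM
Compound 3 `CS(=O)(=O)c1ccc(Cl)cc1NCC1=NCCN1`: < 6310 nM

Of the compounds shown here, three have been measured in an assay on CHO cells for binding affinity to Alpha-2B adrenergic receptor (Homo sapiens), read by radioligand binding; on this read-out higher numbers stand for weaker inhibition and lower numbers for stronger inhibition. For compound 1 the value < 6310 nM is a limit of the assay and not a number. For compound 3 the value < 6310 nM is likewise a limit. For compound 2 the value < 6310 nM is also a limit. Compound 3 differs from compound 1 by chloro in place of fluoro on an aromatic carbon. The step that the two limits leave unreadable from compound 1 to compound 3 cannot be sized, since both ends rest on (the limit of < 6310 nM in this assay, at which 3 of the 3 values shown sit). Compound 1 and compound 2 have the same atoms joined differently; the difference between the two cores is not broken down here.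

Compound 4 `CS(=O)(=O)c1cc(Cl)ccc1NCC1=NCCN1` has not yet been measured in this assay. It differs from compound 2 by chloro in place of fluoro on an aromatic carbon. In compound 4 the changed carbon is meta to a methylsulfonyl group and para to a group of 7 heavy atoms, whereas in compound 3 it is meta to a group of 7 heavy atoms and para to a methylsulfonyl group, so the two changes are the same kind of change, not the same change.

Among the measured compounds shown here, because every value so far sits at the limit of < 6310 nM in this assay, at which 3 of the 3 values shown sit, the step from compound 2 to compound 4 is expected to be small, around a step that the limit leaves unreadable from compound 2 to compound 4. Compound 4 is expected to give about 2000 nM, within 300 nM to 6310 nM, most likely again reported only as a limit.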

Compound 4, inhibition constant: < 6310 nM
Compound 4 was reported as a limit; the forecaster's own chance of this, stated with the estimate: 80%; the middle value does not contradict the limit.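

For compound 4 the value < 6310 nM in this assay is a limit of the assay and not a number. No size can be read for the step between compound 2 and compound 4, because both ends rest on a limit: the limit of < 6310 nM in this assay, at which 4 of the 4 values shown sit.

The compounds shown leave open how strong the inhibition of each of the four actually is, and whether chloro in place of fluoro shifts it at all.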